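Cyanoaryl carbamates of a diphenylmethylpiperidine: methoxy to methyl

A few compounds are considered here, and "the series" means these few. Any claim that something is new, unique, unknown or untested is made for them only; others in the source may bear on it.

Measured compounds:
Compound 1, `N#Cc1ccnc(OC(=O)N2CCC(C(c3ccccc3)c3ccccc3)CC2)c1`: in an assay on isolated protein for inhibition of Fatty-acid amide hydrolase 1 (Rattus norvegicus), read by fluorescence (a higher number here means a weaker inhibitor, a lower number a stronger inhibitor), compound 1 gives > 1000 nM, a limit of the assay.
Compound 2, `N#Cc1cccc(OC(=O)N2CCC(C(c3ccccc3)c3ccccc3)CC2)c1`: in this assay compound 2 gives > 1000 nM, a limit of the assay.
Compound 3, `COc1cc(C#N)cc(OC(=O)N2CCC(C(c3ccccc3)c3ccccc3)CC2)c1`: in this assay compound 3 gives > 1000 nM, a limit of the assay.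

Compound 3 stands at the limit of the assay, and so do the other two measured compounds: the limit of > 1000 nM in this assay, at which 3 of the 3 values shown sit. None of the three steps between them can be read: a step that the two limits leave unreadable from compound 1 to compound 2, a step that the two limits leave unreadable from compound 1 to compound 3 and a step that the two limits leave unreadable from compound 2 to compound 3 are all unreadable in size and direction, since both ends sit at the limit.

Compound 4 is `Cc1cc(C#N)cc(OC(=O)N2CCC(C(c3ccccc3)c3ccccc3)CC2)c1`. It differs from compound 3 in one place: methyl in place of methoxy on an aromatic carbon. The closest measured step, from compound 2 to compound 3, concerns the same aromatic carbon, but its size is not readable. No measured step in this series has shown a readable gain, so the expectation for the step from compound 3 to compound 4 in this assay is that it stays at or near the limit, with a step that the limit leaves unreadable from compound 3 to compound 4 expected as the working guess.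

Compound 4 is therefore expected to give about 3000 nM in this assay, estimated between 800 nM and 20000 nM, most likely again reported only as a limit.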

Compound 4, half-maximal inhibitory concentration: > 1000 nM
Compound 4: a limit, no number; the forecaster's own chance of this, stated with the estimate: 75%; the middle value is on the limit's open side.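

Compound 4 gives > 1000 nM in this assay, a limit of the assay. The steps joining compound 4 to compound 1, compound 2 and compound 3 therefore cannot be read: the limit of > 1000 nM in this assay, at which 4 of the 4 values shown sit.

The compounds shown leave open how strongly any of the four inhibits, and whether hydrogen, methoxy or methyl on that aromatic carbon makes any difference.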